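Triazine ethers: aryl swap toward dichlorophenyl

The compounds below may be only part of what the source reports. "The series", "measured", "known", "first", "only" and "open" are said of these compounds alone.

Measured so far:
compound 1 `NC1=NC2(CCOCC2)N(OCCCOc2ccc(F)cc2)C(N)=N1` — 46.6 nM
compound 2 `Cc1cc(C)cc(OCCCON2C(N)=NC(N)=NC23CCOCC3)c1` — "not determined" (no result reported)

The shared core carries a propoxy linker ending in an aryl ether. In an assay on isolated protein for inhibition of Dihydrofolate reductase (Homo sapiens), read by spectrophotometry, using NADPH, with stated times of 5 s and 6 min (on this read-out higher numbers stand for weaker inhibition and lower numbers for stronger inhibition), compound 1 gives 46.6 nM. For compound 2 this assay reports "not determined" (no result reported); no number stands behind it, so compound 2 has no place on the scale, and nothing can be said about the gap between compound 2 and compound 1.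

Compound 3 `NC1=NC2(CCOCC2)N(OCCCOc2ccc(Cl)c(Cl)c2)C(N)=N1` differs from compound 2 by 3,4-dichlorophenyl in place of 3,5-dimethylphenyl on an oxygen on a saturated carbon. Among the measured compounds shown here, no measured pair isolates this change, so the size of the step in this assay cannot be read from the series. With only compound 1 as an anchor, the expectation is for a value near that of compound 1, any shift toward stronger inhibition staying within or only slightly beyond the usual scatter. Compound 3 is expected to give about 30 nM, with a range from 8 nM to 120 nM.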

Compound 3, half-maximal inhibitory concentration: 8.23 nM
Beside the measured number, compound 3's estimate is 3.6-fold (0.56 log units) above it, within the range that was stated.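

The aryl group on an oxygen on a saturated carbon now proves able to move the result: in this assay the change to 3,4-dichlorophenyl in place of 4-fluorophenyl gives a 5.7-fold lower number from compound 1 to compound 3 (0.75 log units; beyond the scatter) on the shared core, a step beyond the usual scatter. Among the compounds shown here, this is the first readable step, as the step involving compound 2 cannot be read, and 3,5-dimethylphenyl therefore stays unplaced. No supporting measurement bears on why the number falls.

A single pair cannot show whether this step needs both chlorine atoms or whether one would do. It also leaves open how a monochlorophenyl group, a pyridyl ring in place of the phenyl ring, or a longer chain in place of the propoxy linker would read in this assay on this core.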